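Adding a Nitro Group: Cytotoxicity Across Four Compounds

The source may hold more compounds than are shown below. What is called first, only, known or untested is meant among the compounds shown, and "the series" means these compounds.

Compounds 1, 2 and 3 have so far been tested in an ADME assay on HEK-293T cells (Homo sapiens) for cytotoxicity, read by CCK-8 assay, with a stated time of 48 h; on this read-out higher numbers stand for weaker inhibition and lower numbers for stronger inhibition. Compound 1 `COc1ccc(Oc2ccc([N+](=O)[O-])cc2-c2ccsc2S(=O)(=O)N2CCN(C(=S)Nc3ccc(Cl)cc3)CC2)cc1OC` carries a nitro group; in this assay compound 1 gives > 50000 nM, which is a limit of the assay rather than a number. Compound 2 `COc1ccc(Oc2ccccc2-c2ccsc2S(=O)(=O)N2CCN(C(=S)Nc3ccc(Cl)cc3)CC2)cc1OC` lacks that group; in this assay compound 2 gives > 20000 nM, again a limit. The step from compound 2 to compound 1 is a step that the two limits leave unreadable from compound 2 to compound 1, the change being (nitro in place of hydrogen on an aromatic carbon). Its size cannot be read because the two values sit at the limit of > 20000 nM in this assay, at which 2 of the 3 values shown sit, and (the limit of > 50000 nM in this assay, at which 1 of the 3 values shown sits).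

Compound 3 `O=S(=O)(c1sccc1-c1ccccc1Oc1ccc(O)c(O)c1)N1CCN(C(=S)Nc2cc(C(F)(F)F)cc(C(F)(F)F)c2)CC1` has a different core, and how it differs from compound 2 is not broken down here. In this assay compound 3 gives > 20000 nM, which is also a limit. Compound 4 `O=[N+]([O-])c1ccc(Oc2ccc(O)c(O)c2)c(-c2ccsc2S(=O)(=O)N2CCN(C(=S)Nc3cc(C(F)(F)F)cc(C(F)(F)F)c3)CC2)c1` has not been measured. It differs from compound 3 by nitro in place of hydrogen on an aromatic carbon. This is the same kind of change as that from compound 2 to compound 1, though the surroundings differ: there the ring bore a 3,4-dimethoxyphenoxy group, here it bears a 3,4-dihydroxyphenoxy group.

The expected step is a step that the limit leaves unreadable from compound 3 to compound 4, small, resting on the earlier pair, whose values both sit at limits, the limit of > 20000 nM in this assay, at which 2 of the 3 values shown sit, and (the limit of > 50000 nM in this assay, at which 1 of the 3 values shown sits). Compound 4 is therefore estimated at 30000 nM, most probably reported again as a limit rather than a number.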

Compound 4, half-maximal inhibitory concentration: > 20000 nM
Compound 4: no number, only a limit; the forecaster's own chance of this, stated with the estimate: 75%; the middle value does not contradict the limit.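

In this assay compound 4 gives > 20000 nM, which is a limit of the assay and not a number. Compound 3 sits at a limit as well, so no size can be read for the step between compound 3 and compound 4: the limit of > 20000 nM in this assay, at which 3 of the 4 values shown sit.

The compounds shown leave open whether nitro in place of hydrogen on an aromatic carbon changes the result in this assay at all, and how strongly any of the four compounds inhibits.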